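This account rests on a few compounds, and the source may have more. Where it says the series, first, only, none or still open, it means among the compounds named here.

Compound 1 `O=[N+]([O-])c1cn2c(n1)OC[C@H](OCc1ccc(-c3ccc(C(F)(F)F)cc3Cl)cn1)C2`: 299 ug/mL
Compound 2 `O=[N+]([O-])c1cn2c(n1)OC[C@H](OCC#Cc1ccc(-c3ccc(OC(F)(F)F)cc3)cn1)C2`: 3 ug/mL

Both values come from a physicochemical assay for solubility, read by HPLC, measured as kinetic solubility, with a stated time of 15 min, at pH 1; a lower number here means a less soluble compound, a higher number a more soluble compound. Compound 2 gives the lower of the two numbers, and its gap to compound 1 lies well beyond the usual scatter. These two compounds differ in more than one place, so that gap cannot be tied to any single group. Compound 3 `O=[N+]([O-])c1cn2c(n1)OC[C@H](OCC#Cc1ccc(-c3ccc(C(F)(F)F)cc3)cn1)C2` differs from compound 2 in one place: trifluoromethyl in place of trifluoromethoxy on an aromatic carbon. For the measured compounds named here, no measured pair shows this change, so no shift beyond the scatter is expected in this assay. The expected step, a 1.3-fold higher number from compound 2 to compound 3 (0.12 log units; within the scatter), is small. For compound 3 the estimated value is 4 ug/mL, with a range of 1.5 ug/mL to 12 ug/mL.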

Compound 3, solubility: 7.6 ug/mL
Estimate against measurement, compound 3: 1.9-fold (0.28 log units) below; the range from low to high includes it.
By their numbers in this assay, from the lowest: compound 2; then compound 3; then compound 1.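

In this assay, trifluoromethyl in place of trifluoromethoxy gives a 2.5-fold higher number from compound 2 to compound 3 (0.40 log units; beyond the scatter), a modest step. For the compounds shown here, this is the first comparison that changes one place only, and it shows that this position, para to a large group, can move the number when the oxygen of trifluoromethoxy is absent. Nothing measured here bears on the reason for this step. On these data alone, the step rests on a single pair, and whether it holds on a different chain stays open. As far as these compounds go, how an amine at this position would read also remains open.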